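Fluoro in place of chloro in the series

The source may report more compounds than this note shows. Statements on the series, on what has been measured and on what is new or still open speak of the compounds shown alone.

Compound 1 (`Cc1ccnc2nc(-c3cccc4ccccc34)cc(O)c12`) gives < 10 nM in a functional assay on OVCAR-3 cells (Homo sapiens) for antiproliferative activity (on this read-out lower numbers stand for stronger inhibition of growth and higher numbers for weaker inhibition of growth), and this value is a limit of the assay, not a number. Within the data shown here, compound 2 (`Cc1cnc2[nH]c(-c3cccc(Cl)c3)cc(=O)c2c1`) gives 22.4 nM, the only actual number so far. Compound 3 (`Cc1cnc2[nH]c(-c3cccc(F)c3)cc(=O)c2c1`) has fluoro in place of chloro on an aromatic carbon, meta to a large group (fluoro in place of chloro on an aromatic carbon). Among the measured compounds shown here, no measured pair tests this exchange. In this assay a small step toward weaker inhibition of growth is expected, possibly none beyond the scatter. The expected step is a 1.6-fold higher number from compound 2 to compound 3 (0.19 log units; within the scatter). For compound 3 the estimate is 35 nM, with an expected range of 12 nM to 100 nM.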

Compound 3, concentration for 50% growth inhibition: 13.5 nM
Beside the measured number, compound 3's estimate is 2.6-fold (0.41 log units) above it; measured number inside the range.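

In this assay, fluoro in place of chloro on this aromatic carbon gives a 1.7-fold lower number from compound 2 to compound 3 (0.22 log units; within the scatter), so the two halogens cannot be told apart at this position. Among these compounds, this is the first measured single-place pair, and it shows that the position accepts either group with the value held in the same range.

Compound 1 stands at a limit of the assay, not at a number: the limit of < 10 nM in this assay, at which 1 of the 3 values shown sits. On these data alone, how an amine or a methoxy group would read at this position stays open, as does any other place on the shared core.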